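The compounds below may be only part of what the source reports. "The series", "measured", "known", "first", "only" and "open" are said of these compounds alone.

Measured so far:
- compound 1, `Clc1ccc(COc2ccc(OCCOCCNC3CCCC3)cc2)cc1`: 7670 nM
- compound 2, `c1ccc(COc2ccc(OCCOCCNC3CCC3)cc2)cc1`: 25000 nM

Both numbers come from a functional assay on SK-OV-3 cells (Homo sapiens) for inhibition, read by CCK-8 assay, with a stated time of 70 h; on this read-out higher numbers stand for weaker inhibition and lower numbers for stronger inhibition. Among the compounds with values here, compound 1 gives the lowest of the two numbers, and compound 2 gives a number beyond the usual scatter above it; the two compounds differ in more than one place, so no single step connects them, and their values show only that compound 1 is the stronger inhibitor of this pair.

The next compound, compound 3 with structure `O=Cc1ccc(COc2ccc(OCCOCCNC3CCCC3)cc2)cc1`, differs from compound 1 in one place: formyl in place of chloro on an aromatic carbon. Within the data shown here, no measured pair shows this same change, so there is no step to lean on. The expectation is therefore a small step from compound 1, a 1.3-fold higher number from compound 1 to compound 3 (0.12 log units; within the scatter), which is estimated to stay within the usual scatter, with the direction undecided between unchanged and slightly weaker inhibition. For compound 3 in this assay the estimated value is 10000 nM, with a likely range from 3000 nM to 35000 nM.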

Compound 3, half-maximal inhibitory concentration: 45000 nM
Compound 3: middle estimate off by 4.5-fold (0.65 log units), on the low side; the whole stated range lies below it.
By their numbers in this assay, from the lowest: compound 1; then compounds 2 and 3 (each within the scatter of the next).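

In this assay the exchange of chloro for formyl on an aromatic carbon, para to a large group, gives a 5.9-fold higher number from compound 1 to compound 3 (0.77 log units; beyond the scatter) and so weakens inhibition. Within the data shown here, this is the first single-place step, and it shows that this position is not indifferent to the group it carries, even though the amine end and the rest of the molecule stay the same. The change is small in atom count, with two heavy atoms entering for one and a hydrogen-bond acceptor added, yet the step lies beyond the usual scatter, and no measurement at hand accounts for it.

One pair cannot tell whether chloro favours inhibition, formyl disfavours it, or both, and a methyl, a nitrile, a hydroxymethyl or a carboxylic acid in the same place would help to separate these possibilities. From the compounds shown here alone, it also remains open whether the same exchange would give a step of similar size with the cyclobutyl amine of compound 2 in place of the cyclopentyl amine.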